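A few compounds are considered here, and "the series" means these few. Any claim that something is new, unique, unknown or untested is made for them only; others in the source may bear on it.

Values so far in a functional assay on Z-138 cells (Homo sapiens) for antiproliferative activity, with a stated time of 72 h (on this read-out lower numbers stand for stronger inhibition and higher numbers for weaker inhibition), are these:
- compound 1 `CCCC#Cc1cc([C@@H]2O[C@H](CO)[C@@H](O)[C@H]2O)n2ncnc(N)c12` gives 20 nM
- compound 2 `Nc1ncnn2c([C@@H]3O[C@H](CO)[C@@H](O)[C@H]3O)cc(C#Cc3cccs3)c12` gives 50100 nM
- compound 3 `COc1ccc(-c2cc([C@@H]3O[C@H](CO)[C@@H](O)[C@H]3O)n3ncnc(N)c23)cc1` gives 62600 nM

The set shows a 2500-fold higher number from compound 1 to compound 2 (3.40 log units; beyond the scatter) and this large step, beyond the scatter, puts compound 2 far from compound 1. The nearest neighbour of compound 2 appears in a 1.2-fold higher number from compound 2 to compound 3 (0.10 log units; within the scatter) and that step lies within the scatter.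

Compound 4 `Nc1ncnn2c([C@@H]3O[C@H](CO)[C@@H](O)[C@H]3O)cc(/C=C/c3ccccc3)c12` carries 2-phenylethenyl in place of 2-(thiophen-2-yl)ethynyl on an aromatic carbon.

For the measured compounds named here, the closest precedent is the exchange of 2-(thiophen-2-yl)ethynyl for 4-methoxyphenyl at that carbon (a 1.2-fold higher number from compound 2 to compound 3 (0.10 log units; within the scatter)), which stayed within the scatter. The group entering compound 4 also holds an aromatic ring, as do the groups of compound 2 and compound 3. Compound 1 goes against any reading that this place is insensitive, as the large step (a 3100-fold higher number from compound 1 to compound 3 (3.50 log units; beyond the scatter)) shows, but its pent-1-yn-1-yl group holds no ring and is a poorer guide here. Going by the values given here, with only two ring-bearing compounds measured, the range has to stay wide.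

In this assay no step beyond the scatter is expected in either direction, the estimated change being (a 1.3-fold lower number from compound 2 to compound 4 (0.10 log units; within the scatter)). The expected value for compound 4 is 40000 nM (estimated range 8000 nM to 120000 nM).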

Compound 4, half-maximal inhibitory concentration: 1300 nM
For compound 4 the middle estimate is 31-fold (1.49 log units) above the measured one; the whole stated range lies above it.
By their numbers in this assay, from the lowest: compound 1; then compound 4; then compounds 2 and 3 (each within the scatter of the next).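

In this assay the ring-bearing groups at this aromatic carbon do not sit at one level: a 39-fold lower number from compound 2 to compound 4 (1.59 log units; beyond the scatter) and a 48-fold lower number from compound 3 to compound 4 (1.68 log units; beyond the scatter) set 2-phenylethenyl apart from both 2-(thiophen-2-yl)ethynyl and 4-methoxyphenyl, so the presence of an aromatic ring does not by itself fix the number here. The ringless pent-1-yn-1-yl group still gives the lowest number, with a 65-fold higher number from compound 1 to compound 4 (1.81 log units; beyond the scatter), which places compound 4 at an intermediate level, with compound 1 on one side and compounds 2 and 3 on the other. No measurement at hand accounts for these differences.

The change from compound 2 to compound 4 replaces the triple bond with a double bond and the thiophene ring with a benzene ring in one move, so the compounds shown leave open which of the two carries the step; 2-phenylethynyl and 2-(thiophen-2-yl)ethenyl would separate them. Also open, on these data alone, is how a saturated chain such as 2-phenylethyl, or a longer alkyne such as hex-1-yn-1-yl, would read at this carbon.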